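The compounds below may be only part of what the source reports. "The series", "measured", "known", "first", "only" and "open" are said of these compounds alone.

Measured compounds:
compound 1 `O=C(CSc1nnnn1-c1ccccc1)N/N=c1/scc(-c2ccc(Br)cc2)n1-c1ccccc1`, 433 ug/mL
compound 2 `Cn1cnnc1SCC(=O)N/N=c1/scc(-c2ccc(C#N)cc2)n1-c1ccccc1`, 153 ug/mL
compound 3 `Cn1cnnc1SCC(=O)N/N=c1/scc(-c2ccc(F)cc2)n1-c1ccccc1`, 65 ug/mL

In an ADME assay on NIH3T3 cells (Mus musculus) for cytotoxicity, read by MTT assay, with a stated time of 24 h (on this read-out higher numbers stand for weaker inhibition and lower numbers for stronger inhibition), compound 2 stands second highest of the three numbers. Compound 3 gives a lower number, the step being a 2.4-fold lower number from compound 2 to compound 3 (0.37 log units; beyond the scatter). Compound 1 gives the highest number of the three, 433 ug/mL, which lies beyond the scatter from compound 2.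

Compound 4 `N#Cc1ccc(-c2cs/c(=N/NC(=O)CSc3nnnn3-c3ccccc3)n2-c2ccccc2)cc1` differs from compound 2 by 1-phenyl-1H-tetrazol-5-yl in place of 4-methyl-4H-1,2,4-triazol-3-yl on a sulfur. Within the data shown here, no measured step covers this change directly: the only single-point step, a 2.4-fold lower number from compound 2 to compound 3 (0.37 log units; beyond the scatter), concerns a different place on the shared core. Among the measured compounds shown here, compound 1 also carries the 1-phenyl-1H-tetrazol-5-yl group on the sulfur, but it differs from compound 2 in more than one place, so its values show only that the one measured compound bearing that group gives the highest number. On that slender basis compound 4 is expected to move upward from compound 2, with the estimated step of a 1.6-fold higher number from compound 2 to compound 4 (0.21 log units; within the scatter), though a result within the scatter would not surprise. The estimate for compound 4 is 250 ug/mL, in the range 100 ug/mL to 600 ug/mL.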

Compound 4, half-maximal inhibitory concentration: 453 ug/mL
For compound 4 the middle estimate is 1.8-fold (0.26 log units) below the measured one; the measured number falls inside the stated range.
By their numbers in this assay, from the lowest: compound 3; then compound 2; then compounds 1 and 4 (each within the scatter of the next).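

In this assay, 1-phenyl-1H-tetrazol-5-yl in place of 4-methyl-4H-1,2,4-triazol-3-yl on a sulfur is now seen as a change in one place, and it gives a 3.0-fold higher number from compound 2 to compound 4 (0.47 log units; beyond the scatter). With the 1-phenyl-1H-tetrazol-5-yl group on the sulfur, cyano in place of bromo on an aromatic carbon gives a 1.0-fold higher number from compound 1 to compound 4 (0.02 log units; within the scatter), so compounds 1 and 4 cannot be told apart in this assay. No measurement shown here accounts for the step at the sulfur.

The tetrazole ring and its phenyl ring enter together, so the compounds shown do not separate their shares in the step; a tetrazole carrying methyl in place of phenyl would bear on that. Going by these compounds, how an amine or a carboxylic acid on the same chain would read also remains open.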